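The source may hold more compounds than are shown below. What is called first, only, known or untested is meant among the compounds shown, and "the series" means these compounds.

In an ADME assay on microsomes from liver (Homo sapiens) for metabolic stability (on this read-out lower numbers stand for slow clearance and higher numbers for fast clearance), compound 1 `CC(C)Oc1cc(Oc2ccc(S(C)(=O)=O)cc2)cc(-c2cccc(=O)[nH]2)c1` gives < 8 mL/min/kg, which is a limit of the assay and not a number. Compound 2 `Cc1cnc(-c2cc(Oc3ccc(S(C)(=O)=O)cc3)cc(OC(C)C)c2)[nH]c1=O` gives < 8 mL/min/kg, also a limit. For the measured compounds named here, the only measured step, a step that the two limits leave unreadable from compound 1 to compound 2, therefore offers no size to carry forward. Compound 3 `CC(C)Oc1cc(Oc2cnc(C(=O)N(C)C)nc2)cc(-c2nccc(=O)[nH]2)c1` gives < 8 mL/min/kg, again a limit, so its position is known only as a bound. The whole series stands at one boundary: the limit of < 8 mL/min/kg in this assay, at which 3 of the 3 values shown sit.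

Compound 4 `C[C@@H](CO)Oc1cc(Oc2cnc(C(=O)N(C)C)nc2)cc(-c2nccc(=O)[nH]2)c1` differs from compound 3 through (hydroxy in place of hydrogen on a saturated chain carbon, two bonds along the chain from an oxygen on an aromatic ring). Going by the values given here, no measured step covers this change, and none has a readable size. The expectation therefore rests on compound 3 at < 8 mL/min/kg, a limit, and on the small structural change itself. The expected step, a step that the limit leaves unreadable from compound 3 to compound 4, is estimated to stay within the usual scatter of this assay, with no direction expected. A report of compound 4 as a limit again is the likeliest outcome. For compound 4 the estimate is 7 mL/min/kg, with an expected range of 4 mL/min/kg to 14 mL/min/kg.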

Compound 4, clearance: < 8 mL/min/kg
Compound 4 ended at the assay's limit; the forecaster's own chance of this, stated with the estimate: 75%; the middle value lies beyond the limit too.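

In this assay compound 4 gives < 8 mL/min/kg, a limit and not a number, so no size can be read for the change from compound 3 to compound 4. All values shown share one boundary: the limit of < 8 mL/min/kg in this assay, at which 4 of the 4 values shown sit.

The actual clearance of each compound shown remains open, as does any effect of the changes between them.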